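Aryl exchange on the ether chain carbon of compound 1

The source may hold more compounds than are shown below. What is called first, only, known or untested is meant among the compounds shown, and "the series" means these compounds.

Measured so far:
compound 1 `O=C(O)C[C@@H]1CCCN1c1ccc(OCc2ccc(Cl)cc2Cl)cc1`: 4500 nM
compound 2 `Cc1cc(OCc2ccc(Cl)cc2Cl)ccc1N1CCC[C@H]1CC(=O)O`: 14000 nM

In a functional assay on cells for agonist activity at Free fatty acid receptor 1 (Mus musculus), read by FLIPR and calcium flux, with a stated time of 100 s (a lower number here means that less compound is needed, a higher number that more compound is needed for the effect), compound 1 gives 4500 nM, the lower of the two numbers. Compound 2 gives 14000 nM. Within the data shown here, the one measured step, a 3.1-fold higher number from compound 1 to compound 2 (0.49 log units; beyond the scatter), is a methyl in place of hydrogen on an aromatic carbon of the shared core; it runs towards a higher number and is beyond the scatter.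

Compound 3 `Cc1ccccc1COc1ccc(N2CCC[C@H]2CC(=O)O)cc1` differs from compound 1 by 2-methylphenyl in place of 2,4-dichlorophenyl on a saturated chain carbon bound to an oxygen on an aromatic ring. Among the measured compounds shown here, no measured step touches this place: the step from compound 1 to compound 2 sits on the core, not on the chain carbon bound to the ring oxygen, so it gives no direct precedent for the size or direction here. Two chlorines leave and a methyl enters on the ring at the end of the ether chain. With only an indirect reference, the expectation is a modest rise in the number, a 2.2-fold higher number from compound 1 to compound 3 (0.35 log units; beyond the scatter), and a wide range. Compound 3 is therefore estimated at 10000 nM, within 3000 nM to 35000 nM.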

Compound 3, half-maximal effective concentration: 3400 nM
Beside the measured number, compound 3's estimate is 2.9-fold (0.47 log units) above it; measured number inside the range.
By their numbers in this assay, from the lowest: compounds 3 and 1 (each within the scatter of the next); then compound 2.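

In this assay the exchange of 2,4-dichlorophenyl for 2-methylphenyl on a saturated chain carbon bound to an oxygen on an aromatic ring gives a 1.3-fold lower number from compound 1 to compound 3 (0.12 log units; within the scatter), so compound 1 and compound 3 cannot be told apart in this read-out. Among these compounds, this is the first measured change at this place, and it shows that the two chlorines can leave and a methyl can enter without a shift beyond the scatter, whereas the only earlier step, on the core, did go beyond it. No measurement given here bears on why these two aryl groups read alike.

Still open, as far as these compounds go, is whether a different group on this ring, such as a single chlorine, a methoxy group or a trifluoromethyl group, would move the number beyond the scatter, or whether a longer chain between the ring and the oxygen would do so. Also open is whether the step of a 3.1-fold higher number from compound 1 to compound 2 (0.49 log units; beyond the scatter) on the core carries over when 2-methylphenyl stands in place of 2,4-dichlorophenyl, since the compounds shown do not combine the two changes.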